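This account rests on a few compounds, and the source may have more. Where it says the series, first, only, none or still open, it means among the compounds named here.

For the measured compounds named here, compound 1 `CCCCCCSc1n[nH]c(-n2[se]c3ccccc3c2=O)n1` gives 35900 nM in a functional assay on HeLa cells (Homo sapiens) for antiproliferative activity, read by CCK-8 assay, with a stated time of 48 h (a lower number here means a stronger inhibitor, a higher number a weaker inhibitor), the higher of the two numbers measured so far, although compound 2 `CC(C)Sc1n[nH]c(-n2[se]c3ccccc3c2=O)n1` lies within the scatter of it at 34600 nM. The step of a 1.0-fold lower number from compound 1 to compound 2 (0.02 log units; within the scatter) put isopropyl in place of hexyl on a sulfur. Compound 3 `CCCSc1n[nH]c(-n2[se]c3ccccc3c2=O)n1` differs from compound 1 by hydrogen in place of propyl on a saturated chain carbon, three bonds along the chain from a sulfur. That earlier step is the only one that bears on this change, and it lay within the scatter, so no step beyond the scatter is expected in this assay. Compound 3 is therefore estimated at 35000 nM, with a range from 17000 nM to 70000 nM. The expected step is a 1.0-fold lower number from compound 1 to compound 3 (0.01 log units; within the scatter).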

Compound 3, half-maximal inhibitory concentration: 30400 nM
The estimate for compound 3 lay 1.2-fold (0.06 log units) above the measured number; the range from low to high includes it.
By their numbers in this assay, from the lowest: compounds 3, 2 and 1 (each within the scatter of the next).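

In this assay the group on the sulfur now appears in three forms, and neither new change moves the number beyond the scatter: hexyl to propyl gives a 1.2-fold lower number from compound 1 to compound 3 (0.07 log units; within the scatter) and isopropyl to propyl gives a 1.1-fold lower number from compound 2 to compound 3 (0.06 log units; within the scatter). Among these compounds, therefore, neither the difference between propyl and hexyl nor that between propyl and isopropyl separates the values. No evidence bearing on this result is at hand. The compounds shown leave open whether methyl, an amine or a carboxylic acid on the sulfur would move the number beyond the scatter.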